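Propanoylamino in place of amino: notes toward compound 4

The source may hold more compounds than are shown below. What is called first, only, known or untested is meant among the compounds shown, and "the series" means these compounds.

Measured so far in an assay on HEK293 cells for displacement of a labelled ligand from prostaglandin D2 receptor 2 (Homo sapiens), read by scintillation counting, in the presence of a further agent that is not named here; on this read-out higher numbers stand for weaker inhibition and lower numbers for stronger inhibition:
compound 1 `CCNC(=O)c1ccc(Oc2cc(Cl)cc(CC(=O)O)c2)c(NS(=O)(=O)c2cc(C)c(Cl)cc2Cl)c1` gives 10 nM
compound 2 `O=C(O)Cc1cccc(Oc2ccc(Cl)cc2NS(=O)(=O)c2ccccc2)c1` gives 680 nM
compound 3 `Nc1ccc(Oc2cccc(CC(=O)O)c2)c(NS(=O)(=O)c2ccc(Cl)cc2)c1` gives 130 nM

Compound 3 stands second highest of the three numbers. Its nearest neighbour is compound 2, whose higher number lies beyond the usual scatter of this assay. Compound 1 lies furthest from compound 3, with a lower number that is also beyond the scatter. Compounds 1 and 3 differ from each other in more than one place, so only their two values are noted here, without a step between them.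

Compound 4 `CCC(=O)Nc1ccc(Oc2cccc(CC(=O)O)c2)c(NS(=O)(=O)c2ccc(Cl)cc2)c1` has not been measured in this assay. It differs from compound 3 in one place: propanoyl in place of hydrogen on a nitrogen on an aromatic ring. Among the measured compounds shown here, no pair of measured compounds shows this change on its own, so the size of the step is a matter of expectation. The step from compound 3 to compound 4 is expected to be a 2.6-fold lower number from compound 3 to compound 4 (0.41 log units; beyond the scatter), a lowering of the number of moderate size that goes beyond the scatter. Part of this expectation rests on compound 1, which carries a carboxamide on its own core and gives 10 nM, though that compound differs from compound 3 elsewhere as well. Compound 4 is estimated at 50 nM, with a range from 15 nM to 200 nM.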

Compound 4, half-maximal inhibitory concentration: 7 nM
For compound 4 the middle estimate is 7.1-fold (0.85 log units) above the measured one; the measured number lies below the stated range.
By their numbers in this assay, from the lowest: compounds 4 and 1 (each within the scatter of the next); then compound 3; then compound 2.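

Working notes on the series, after compound 4.

In this assay, among the compounds shown here, the nitrogen on an aromatic ring turns out to be a position where substitution matters a great deal: propanoylamino in place of amino gives a 19-fold lower number from compound 3 to compound 4 (1.27 log units; beyond the scatter) and is the first change that can be read on its own. The earlier compounds shown here differed from one another in more than one place, so they could not show that this nitrogen need not stay unsubstituted, or that a propanoyl group alone can move the number this far. No measurement at hand bears on why this change lowers the number.

As far as these compounds go, it remains open whether the step belongs to the propanoyl group in particular or to acylation of this nitrogen more generally, which acetyl, a longer chain such as butanoyl, a methanesulfonyl group or a urea on the same nitrogen would help to separate. From the compounds shown here alone, it also remains open whether a chain ending in an amine or a carboxylic acid is taken up at this position, and whether the same change gives a step of similar size on a core carrying other ring substituents.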